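Isopropyl in place of (tert-butoxycarbonyl)methyl on an amine nitrogen

The source may hold more compounds than are shown below. What is called first, only, known or untested is meant among the compounds shown, and "the series" means these compounds.

Measured in a functional assay (strain AB) with Danio rerio as the target, read by microscopy, with a stated time of 1 h; on this read-out lower numbers stand for an effect already at smaller amounts and higher numbers for an effect only at larger amounts of compound:
- Compound 1 `NC(=O)c1c(NC(=O)Nc2ccc(Cl)cc2)sc2c1CCN(CC1CCC1)C2`: 1360 nM
- Compound 2 `CC(C)(C)OC(=O)N1CCc2c(sc(NC(=O)Nc3ccc(Cl)cc3)c2C(N)=O)C1`: > 25000 nM, a limit of the assay
- Compound 3 `CC(C)(C)OC(=O)CN1CCc2c(sc(NC(=O)Nc3ccc(Cl)cc3)c2C(N)=O)C1`: > 25000 nM, a limit of the assay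

Compound 3 stands at the limit of > 25000 nM in this assay, at which 2 of the 3 values shown sit, so its place is known only as a limit and not as a number.

Compound 4 `CC(C)N1CCc2c(sc(NC(=O)Nc3ccc(Cl)cc3)c2C(N)=O)C1` differs from compound 3 in one place: isopropyl in place of (tert-butoxycarbonyl)methyl on an amine nitrogen in a ring. Isopropyl takes the place of (tert-butoxycarbonyl)methyl on an amine nitrogen in a ring.

Two measured steps at this nitrogen bear on the change, and both are large. One is an at least 18-fold higher number from compound 1 to compound 3 (1.26 log units; beyond the scatter). The other is an at least 18-fold higher number from compound 1 to compound 2 (1.26 log units; beyond the scatter). The third, a step that the two limits leave unreadable from compound 2 to compound 3, adds nothing on size.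

Only compound 1 gives a number, and like compound 4 it carries no tert-butoxycarbonyl on that nitrogen. On the strength of an at least 18-fold higher number from compound 1 to compound 3 (1.26 log units; beyond the scatter), a large step to a lower number is expected in this assay, towards the value of compound 1 at 1360 nM. Among the measured compounds shown here, with only one such compound to go on, this remains an expectation, and another limit reading cannot be ruled out.

The step expected is an at least 8.3-fold lower number from compound 3 to compound 4 (0.92 log units; beyond the scatter). For compound 4 the estimated value is 3000 nM, with an expected range from 800 nM to 15000 nM.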

Compound 4, half-maximal effective concentration: 1490 nM
The estimate for compound 4 lay 2.0-fold (0.30 log units) above the measured number, within the range that was stated.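

In this assay, isopropyl on this amine nitrogen in a ring gives a measured number where tert-butoxycarbonyl and (tert-butoxycarbonyl)methyl gave none, with an at least 16-fold lower number from compound 2 to compound 4 (1.22 log units; beyond the scatter) and an at least 16-fold lower number from compound 3 to compound 4 (1.22 log units; beyond the scatter). Cyclobutylmethyl had been the only group at this nitrogen with a number, and isopropyl now gives a second one, with a 1.1-fold higher number from compound 1 to compound 4 (0.04 log units; within the scatter), so these two groups cannot be told apart on this read-out and a number here is not confined to cyclobutylmethyl. Compound 2 and compound 3 remain limits of the assay and not numbers, so the steps to compound 4 give only a minimum size: the limit of > 25000 nM in this assay, at which 2 of the 4 values shown sit.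

Among the compounds shown here, the two groups that give numbers carry no carbonyl and the two that give limits do, but with only two compounds on each side it stays open whether the carbonyl, the tert-butyl part or something else sets this difference. Also open, going by these compounds, is whether methyl, a longer chain or a carboxylic acid on this nitrogen would give a number in this assay.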